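Swapping a carbamate for a cyclobutyl amide

The source may report more compounds than this note shows. Statements on the series, on what has been measured and on what is new or still open speak of the compounds shown alone.

Of the compounds shown here, two share a core and have been tested in an assay on isolated protein for inhibition of Gonadotropin-releasing hormone receptor (Rattus norvegicus); a higher number here means a weaker inhibitor, a lower number a stronger inhibitor. Compound 1 `CCCCCn1c(SCc2cc([N+](=O)[O-])ccc2OC)nc2cc(NC(=O)NC(C)(C)C)ccc21` gives 880 nM. Compound 2 `COc1ccc([N+](=O)[O-])cc1CSc1nc2cc(NC(=O)OC(C)(C)C)ccc2n1C(C)C` gives 710 nM, which is the lower of the two numbers, though the gap to compound 1 lies within the usual scatter, so the two cannot be ranked. Compound 3 `COc1ccc([N+](=O)[O-])cc1CSc1nc2cc(NC(=O)C3CCC3)ccc2n1C(C)C` has not been measured yet. It differs from compound 2 in a single place: cyclobutyl in place of tert-butoxy on a carbonyl carbon. Among the compounds with values here, no comparable step between measured compounds is available, so the expectation rests on the two values alone. For compound 3 in this assay a step of a 1.3-fold higher number from compound 2 to compound 3 (0.10 log units; within the scatter) is expected, that is, a change too small to stand out from the scatter, since the two measured values already sit close together. Compound 3 is thus estimated at 900 nM, with a range from 300 nM to 2700 nM.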

Compound 3, half-maximal inhibitory concentration: 630 nM
Estimate against measurement, compound 3: 1.4-fold (0.15 log units) above; the measured number falls inside the stated range.
By their numbers in this assay, from the lowest: compounds 3, 2 and 1 (each within the scatter of the next).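

In this assay, within the data shown here, the swap gives the first step that can be read for a single change: a 1.1-fold lower number from compound 2 to compound 3 (0.05 log units; within the scatter). On this carbonyl carbon, whose other neighbour is an amide-type nitrogen, tert-butoxy and cyclobutyl therefore cannot be told apart, even though the change removes a hydrogen-bond acceptor and brings in a four-membered ring. Nothing available explains why the number stays within the scatter.

This single pair does not show how far that tolerance extends, and compound 1 differs from both compounds in more than one place, so it cannot help. Still open, as far as these compounds go, is whether a quite different group on this carbonyl carbon, such as an amine, a carboxylic acid or a longer chain, would give a number clearly apart from these.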